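This account rests on a few compounds, and the source may have more. Where it says the series, first, only, none or still open, it means among the compounds named here.

Measured so far in a functional assay for agonist activity at Free fatty acid receptor 1 (Homo sapiens); a higher number here means that more compound is needed for the effect, a lower number that less compound is needed:
compound 1 `O=C(O)CCc1ccc(NCc2ccc(-c3ccccc3)cc2)cc1` gives 251 nM
compound 2 `O=C(O)CCc1ccc(NCc2ccccc2)cc1` gives 7940 nM

Compound 2 holds the higher of the two numbers, so it needs more compound for the effect; the step from compound 1 to compound 2 is a 32-fold higher number from compound 1 to compound 2 (1.50 log units; beyond the scatter). Compound 3 `N#Cc1ccc(CNc2ccc(CCC(=O)O)cc2)cc1` differs from compound 2 by cyano in place of hydrogen on an aromatic carbon, placed para to a large group. For the measured compounds named here, no measured step changes a hydrogen into a cyano, so only the step of a 32-fold higher number from compound 1 to compound 2 (1.50 log units; beyond the scatter) bears on this position, and it shows that a group there can move this assay strongly. A cyano is expected to lower the number by less than a phenyl did. Compound 3 is estimated at 2500 nM, between 800 nM and 8000 nM, an expected step of a 3.2-fold lower number from compound 2 to compound 3 (0.50 log units; beyond the scatter).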

Compound 3, half-maximal effective concentration: < 31700 nM
Compound 3 ended at the assay's limit; the forecaster's own chance of this, stated with the estimate: 5%; the middle value is on the limit's open side.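

For the compounds shown here, compound 3 gave a limit, not a number, so no step from compound 1 or compound 2 to compound 3 can be read: the limit of < 31700 nM in this assay, at which 1 of the 3 values shown sits. On these data alone, how far cyano in place of hydrogen moves the number stays open.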